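A few compounds are considered here, and "the series" means these few. Any claim that something is new, unique, unknown or untested is made for them only; others in the source may bear on it.

Compound 2, `C#CCCCCOc1cc(O)c(C(C)=O)cc1CC=C`, belongs to a small set of two compounds sharing one core. In an assay on isolated protein for binding affinity to leukotriene B4 receptor 1 (Homo sapiens), tested at 1 uM (a higher number here means more inhibition at the concentration tested (going by the name of the read-out), a lower number less inhibition), compound 2 gives 29%. Its companion compound 1, `C=CCCCCOc1cc(O)c(C(C)=O)cc1CC=C`, gives in this assay 27%, and the two numbers lie within the usual scatter of each other, so the inhibition in this assay is level between the two. For the measured compounds named here, the only measured step, a number 2 percentage points higher from compound 1 to compound 2 (within the scatter), is therefore a change in the chain that left the read-out essentially unmoved.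

Compound 3, `C=CCc1cc(C(C)=O)c(O)cc1OCCCCO`, has not yet been measured in this assay. It differs from compound 2 in one place: hydroxy in place of ethynyl on a saturated chain carbon, four bonds along the chain from an oxygen on an aromatic ring. Going by the values given here, no measured step swaps a carbon group for an oxygen-bearing group, so the one known step gives only weak guidance, namely that a change at this chain position need not move the number. The step from compound 2 to compound 3, a number 3 percentage points lower from compound 2 to compound 3 (within the scatter), is expected to stay within the scatter, with a wide range to reflect the untested kind of change. For compound 3 the estimate in this assay is 26%, between 10% and 42%.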

Compound 3, a percentage reported as inhibition, at one concentration (the size of the read-out at that concentration, not a potency): 9%
Compound 3: the middle estimate sits 17 percentage points above what was measured, and the stated range ends above it.
By their numbers in this assay, from the lowest: compound 3; then compounds 1 and 2 (each within the scatter of the next).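

On a saturated chain carbon, four bonds along the chain from an oxygen on an aromatic ring, the group does matter in this assay: there is a number 20 percentage points lower from compound 2 to compound 3 (beyond the scatter) and also a number 18 percentage points lower from compound 1 to compound 3 (beyond the scatter). Vinyl and ethynyl are thus interchangeable at this place, while hydroxy, which brings one hydrogen-bond donor and one hydrogen-bond acceptor where ethynyl has neither, goes with clearly less inhibition at the concentration tested and gives the lowest number of the three compounds. No independent measurement here explains this drop.

The hydroxy group also has fewer heavy atoms than ethynyl, so these three compounds cannot separate the effect of its oxygen from that of losing carbon at the end of the chain. A methoxy group, an amine or a carboxylic acid at this place, or a longer chain carrying the hydroxy group, would be needed to show whether the low number belongs to hydroxy alone or to a wider range of groups.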